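A few compounds are considered here, and "the series" means these few. Any claim that something is new, unique, unknown or untested is made for them only; others in the source may bear on it.

Measured compounds:
Compound 1, `COc1ccccc1C(=O)/C=C/c1ccc2c(c1)B(O)OC2`, gives 5000 nM in a functional assay on HCT-116 cells (Homo sapiens) for cytotoxicity, read by MTT assay, with a stated time of 48 h; a higher number here means a weaker inhibitor, a lower number a stronger inhibitor.
Compound 2, `COc1cccc(C(=O)/C=C/c2ccc3c(c2)B(O)OC3)c1`, gives 5000 nM in this assay.
Compound 3, `COc1ccc(C(=O)/C=C/c2ccc3c(c2)B(O)OC3)c(OC)c1`, gives 16200 nM in this assay.

Compound 1 and compound 3 share a core. Going from compound 1 to compound 3 the change is methoxy in place of hydrogen on an aromatic carbon and it produced a 3.2-fold higher number from compound 1 to compound 3 (0.51 log units; beyond the scatter). Compound 2 is built from the same atoms as compound 1, joined differently; the difference between the two cores is not broken down here. Compound 2 stands level with compound 1 at the digits given, and together they are the lowest of the three numbers.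

Compound 4, `COc1ccc(C(=O)/C=C/c2ccc3c(c2)B(O)OC3)cc1OC`, has not yet been measured. It differs from compound 2 by methoxy in place of hydrogen on an aromatic carbon. This is the same kind of change as that from compound 1 to compound 3, but not the same: in compound 4 the entering methoxy is ortho to a methoxy group, whereas in compound 3 it is meta to a methoxy group. The step from compound 2 to compound 4 in this assay is expected to be about a 2.4-fold higher number from compound 2 to compound 4 (0.38 log units; beyond the scatter) because the matching change gave a 3.2-fold higher number from compound 1 to compound 3 (0.51 log units; beyond the scatter). Compound 4 is therefore estimated at 12000 nM, likely between 5000 nM and 30000 nM.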

Compound 4, half-maximal inhibitory concentration: 12200 nM
For compound 4 the middle estimate is 1.0-fold (0.01 log units) below the measured one, within the range that was stated.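

Adding a methoxy group in place of a hydrogen on the aromatic ring of compound 2 raised the number in this assay, giving a 2.4-fold higher number from compound 2 to compound 4 (0.39 log units; beyond the scatter), and the same kind of change on the other core moved the number the same way, by an amount that cannot be told apart from this step: the same change on two cores in this assay, a 3.2-fold higher number (0.51 log units; beyond the scatter) from compound 1 to compound 3 and a 2.4-fold higher number (0.39 log units; beyond the scatter) from compound 2 to compound 4, 1.3-fold (0.12 log units) apart, within the scatter of two such steps. In these two pairs, then, the change carries over from one core to the other, and in both it goes with a weaker result in this cell assay. For the compounds shown here, this does not show that it would carry over to further cores or to other places on the ring, since it rests on only two pairs, and it does not explain why the number rises.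

As far as these compounds go, it remains open whether an amine, a carboxylic acid or a longer chain such as ethoxy would behave like methoxy at these places. From the compounds shown here alone, it is also open whether a hydroxy group there would keep or lose the higher number.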